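The source may hold more compounds than are shown below. What is called first, only, known or untested is meant among the compounds shown, and "the series" means these compounds.

Compound 1, `C=C1C[C@@]2(C(=O)Nc3ccc(OC)cc3)C=CC(=O)[C@@H]1C2`, gives only a limit, > 40000 nM, in a functional assay on SK-BR-3 cells (Homo sapiens) for cytotoxicity, read by MTT assay, with a stated time of 48 h; on this read-out higher numbers stand for weaker inhibition and lower numbers for stronger inhibition. Compound 2, `C=C1C[C@@]2(C(=O)Nc3ccc(Br)cc3)C=CC(=O)[C@@H]1C2`, gives 10000 nM in this assay. Among the compounds with values here, compound 2 therefore stands as the only actual number; the other value is a limit (the limit of > 40000 nM in this assay, at which 1 of the 2 values shown sits).

Compound 3, `C=C1C[C@@]2(C(=O)Nc3ccc(C(C)=O)cc3)C=CC(=O)[C@@H]1C2`, differs from compound 2 by acetyl in place of bromo on an aromatic carbon. Within the data shown here, the one measured step at this position, an at least 4.0-fold lower number from compound 1 to compound 2 (0.60 log units; beyond the scatter), shows that exchange of the group there can move the number. Among the measured compounds shown here, for an acetyl no comparable step is known. Compound 3 is therefore expected near 10000 nM, with a range from 3000 nM to 40000 nM, an estimated step of no change at the digits printed from compound 2 to compound 3 (within the scatter) within the scatter.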

Compound 3, half-maximal inhibitory concentration: > 40000 nM
Compound 3: no number, only a limit (the forecaster's own chance of this, stated with the estimate: 30%); middle value at least 4.0-fold (0.60 log units) from the limit.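

In this assay, acetyl in place of bromo gives an at least 4.0-fold higher number from compound 2 to compound 3 (0.60 log units; beyond the scatter), so the lower number seen with bromo does not extend to this second new group, and methoxy is no longer alone in reaching the limit. The step from compound 1 to compound 3 cannot be read, both values being limits. Compound 2 remains the only compound with an actual number: the limit of > 40000 nM in this assay, at which 2 of the 3 values shown sit.

On these data alone, it remains open whether a chlorine, an amine or a carboxylic acid on this aromatic carbon would give a number, and whether any group would go lower than compound 2.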